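The source may hold more compounds than are shown below. What is called first, only, known or untested is meant among the compounds shown, and "the series" means these compounds.

Notes on the series, step from compound 3 to compound 4.

The shared core carries an aryl amide on one side and a substituent on the ring nitrogen on the other. In a functional assay on MKN-74 cells (Homo sapiens) for antiproliferative activity, with a stated time of 24 h (a lower number here means a stronger inhibitor, a higher number a weaker inhibitor), compound 1 `NC(=O)c1c(NC(=O)c2ccc(C(F)(F)F)cc2)sc2c1CCN(Cc1ccc(Cl)cc1Cl)C2` gives 10900 nM, compound 2 `NC(=O)c1c(NC(=O)c2ccccc2F)sc2c1CCN(Cc1cccc(Cl)c1)C2` gives 23300 nM, and compound 3 `NC(=O)c1c(NC(=O)c2ccccc2F)sc2c1CCN(Cc1ccc(Cl)cc1Cl)C2` gives 9610 nM. Going by the values given here, compound 3 has the lowest of the three numbers, but the gap to compound 1 is within the scatter; only the step of a 2.4-fold lower number from compound 2 to compound 3 (0.38 log units; beyond the scatter) is beyond it, and the step of a 1.1-fold lower number from compound 1 to compound 3 (0.05 log units; within the scatter) is not.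

Compound 4 `NC(=O)c1c(NC(=O)c2ccccc2F)sc2c1CCN(C(=O)Nc1ccccc1Cl)C2` differs from compound 3 by (2-chlorophenyl)carbamoyl in place of 2,4-dichlorobenzyl on an amine nitrogen in a ring. Among the compounds with values here, of the two steps seen so far, only a 2.4-fold lower number from compound 2 to compound 3 (0.38 log units; beyond the scatter) touches the same place, and it exchanged one benzyl group for another; no measured pair exchanges the benzyl group for a carbamoyl, so there is no direct guide to the size or direction of the step. The change at this position is larger than any seen so far, and an expectation can only be loose: the number for compound 4 is estimated to stay near that of compound 3, with a wide range, so that the step of a 1.6-fold higher number from compound 3 to compound 4 (0.19 log units; within the scatter) is expected to fall within or just beyond the scatter in either direction. Compound 4 is therefore estimated at 15000 nM, with a range from 4000 nM to 60000 nM.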

Compound 4, half-maximal inhibitory concentration: 49600 nM
Beside the measured number, compound 4's estimate is 3.3-fold (0.52 log units) below it, and the stated range covers the measured number.
By their numbers in this assay, from the lowest: compounds 3 and 1 (each within the scatter of the next); then compound 2; then compound 4.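

In this assay, the amine nitrogen in a ring now shows a response to a change in the type of substituent, not only to an exchange of one benzyl group for another: (2-chlorophenyl)carbamoyl in place of 2,4-dichlorobenzyl gives a 5.2-fold higher number from compound 3 to compound 4 (0.71 log units; beyond the scatter), and in place of 3-chlorobenzyl it gives a 2.1-fold higher number from compound 2 to compound 4 (0.33 log units; beyond the scatter). Both steps run the same way, towards a weaker inhibitor, so among these three compounds the carbamoyl compares unfavourably with either benzyl group, and the first of the two steps is larger than a 2.4-fold lower number from compound 2 to compound 3 (0.38 log units; beyond the scatter) seen for the benzyl exchange. Nothing available on the series accounts for these steps.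

Going by these compounds alone, the carbamoyl is seen only with the 2-fluorophenyl amide, so it remains open whether the same step would hold with the 4-(trifluoromethyl)phenyl amide of compound 1. Also open, as far as these compounds go, is how this position would answer to a plain acetyl, a benzoyl or a longer chain such as 2-phenylethyl, and whether the carbamoyl's step would change with the chlorine moved elsewhere on its phenyl ring or replaced by a methoxy group.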